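Methoxy for chloro on the pyrazole aryl ring

The compounds below may be only part of what the source reports. "The series", "measured", "known", "first", "only" and "open" are said of these compounds alone.

Measured compounds:
Compound 1 `CC(=O)N1N=C(c2ccc(F)cc2)CC1c1cn(-c2ccccc2)nc1-c1ccc(Cl)cc1` gives 44% in a functional assay on the whole organism (Tail) with Rattus norvegicus as the target, in the tail flick test, with a stated time of 60 min, at a dose of 25 mg/kg by the oral route; a lower number here means less inhibition, a higher number more inhibition at the dose given (going by the name of the read-out).
Compound 2 `CC(=O)N1N=C(c2ccc(F)cc2)CC1c1cn(-c2ccccc2)nc1-c1cccc([N+](=O)[O-])c1` gives 109% in this assay.
Compound 3 `Fc1ccc(C2=NN(c3ccccc3)C(c3cn(-c4ccccc4)nc3-c3ccc(Cl)cc3)C2)cc1` gives 43% in this assay.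

Compound 3 stands lowest of the three numbers, though compound 1 sits within the scatter of it, as a number 1 percentage points lower from compound 1 to compound 3 (within the scatter) shows. Compound 4 `COc1ccc(-c2nn(-c3ccccc3)cc2C2CC(c3ccc(F)cc3)=NN2c2ccccc2)cc1` differs from compound 3 in one place: methoxy in place of chloro on an aromatic carbon. Within the data shown here, no measured step shows this exchange. Among the measured compounds shown here, the only step that touches the same aryl ring is a number 65 percentage points higher from compound 1 to compound 2 (beyond the scatter), which shows that the ring can move the read-out strongly, but in that case a different group entered at a different place. Compound 3 is expected to remain near its own value, so for compound 4 a step of a number 7 percentage points higher from compound 3 to compound 4 (within the scatter) is estimated, with wide uncertainty. Compound 4 is therefore estimated at 50%, between 20% and 85%.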

Compound 4, a percentage reported as inhibition, in the whole organism at one dose (the size of the read-out at that dose, not a potency): 66%
For compound 4 the middle estimate is 16 percentage points below the measured one, within the range that was stated.
By their numbers in this assay, from the lowest: compounds 3 and 1 (each within the scatter of the next); then compound 4; then compound 2.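

In this assay the change from 4-chlorophenyl to 4-methoxyphenyl gives a number 23 percentage points higher from compound 3 to compound 4 (beyond the scatter) and so shows that replacing the group at this one aromatic carbon, with its place unchanged, moves the read-out beyond the scatter. The earlier step on this ring, a number 65 percentage points higher from compound 1 to compound 2 (beyond the scatter), changed both the group and its place, so it could not show this. No measurement shown explains the rise.

From the compounds shown here alone, whether an amine or a hydroxyl group at this carbon would raise the read-out further remains open. So does whether the same exchange would give a similar step with the acetyl group of compound 1 on the ring nitrogen.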